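A few compounds are considered here, and "the series" means these few. Any claim that something is new, unique, unknown or untested is made for them only; others in the source may bear on it.

Measured compounds:
compound 1 `Oc1cc(-c2ccc3ccccc3c2)nc2ncccc12` gives 10500 nM
compound 2 `Cc1ccnc2nc(-c3cccc4ccccc34)cc(O)c12` gives 20 nM
compound 3 `Cc1cc(C)c2c(O)cc(-c3cccc4ccccc34)nc2n1` gives 759 nM

Compound 4 `Cc1ccnc2nc(-c3ccc4ccccc4c3)cc(O)c12` has not yet been measured in a functional assay on PC-3 cells (Homo sapiens) for antiproliferative activity; a lower number here means a stronger inhibitor of growth, a higher number a weaker inhibitor of growth. It arises from compound 1 by methyl in place of hydrogen on an aromatic carbon. The same kind of change is found from compound 2 to compound 3, (methyl in place of hydrogen on an aromatic carbon), where the methyl enters next to the ring nitrogen rather than opposite it and ortho to a fused ring; that step was a 38-fold higher number from compound 2 to compound 3 (1.58 log units; beyond the scatter). The difference between the core of compound 1 and the core of compound 2 is not broken down here. Compound 1 stands with the highest number of the three, and compound 2 with the lowest. Among the measured compounds shown here, the only measured methyl step lies at another place, so its size is taken as a loose guide only. For compound 1 to compound 4 a step of a 2.6-fold lower number from compound 1 to compound 4 (0.42 log units; beyond the scatter) is expected, a modest gain rather than the loss seen next to the nitrogen. Compound 4 is therefore estimated at 4000 nM, within 600 nM to 20000 nM.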

Compound 4, concentration for 50% growth inhibition: 1380 nM
Compound 4: middle estimate off by 2.9-fold (0.46 log units), on the high side; the measured number falls inside the stated range.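

In this assay, methyl in place of hydrogen on an aromatic carbon, opposite the ring nitrogen, gives a 7.6-fold lower number from compound 1 to compound 4 (0.88 log units; beyond the scatter). Set beside the earlier methyl step, this change does not carry over from one core to another in size or in direction: the same change on two cores in this assay, a 38-fold higher number (1.58 log units; beyond the scatter) from compound 2 to compound 3 and a 7.6-fold lower number (0.88 log units; beyond the scatter) from compound 1 to compound 4, 290-fold (2.46 log units) apart, beyond the scatter of two such steps. The two steps also differ in where the methyl enters, and these compounds do not separate the effect of the core from that of the place, so only this one pair of steps is shown to disagree, and no general rule for methyl follows.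

Open, on these data alone, is whether an ethyl, a methoxy or an amine opposite the ring nitrogen on the core of compound 1 would follow the step to compound 4.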